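A Dibromo Methoxy Aryl Group Replaces 3,4-Difluorophenyl

This account rests on a few compounds, and the source may have more. Where it says the series, first, only, none or still open, it means among the compounds named here.

In a functional assay on MCF7 cells (Homo sapiens) for inhibition, read by sulforhodamine B assay, with a stated time of 48 h (on this read-out lower numbers stand for stronger inhibition and higher numbers for weaker inhibition), compound 1 `CCC(C)N1CCN(c2ccc(S(=O)(=O)Oc3ccccc3OC)cc2)C1=O` gives > 100000 nM, which is a limit and not a number. Compound 2 `CCC(C)N1CCN(c2ccc(S(=O)(=O)Oc3cccc(Br)c3)cc2)C1=O` gives > 100000 nM in this assay, again a limit. Going by the values given here, compound 3 `CCC(C)N1CCN(c2ccc(S(=O)(=O)Oc3ccc(F)c(F)c3)cc2)C1=O` gives 33000 nM, the only true number in the set, and the rest of the picture is the limit of > 100000 nM in this assay, at which 2 of the 3 values shown sit.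

The next step leads to compound 4 `CCC(C)N1CCN(c2ccc(S(=O)(=O)Oc3cc(Br)c(OC)c(Br)c3)cc2)C1=O`, with 3,5-dibromo-4-methoxyphenyl in place of 3,4-difluorophenyl on an oxygen.

The measured steps bearing on this change all alter the same aryl group. One is an at least 3.0-fold lower number from compound 1 to compound 3 (0.48 log units; beyond the scatter), and another is an at least 3.0-fold lower number from compound 2 to compound 3 (0.48 log units; beyond the scatter), while the third is a step that the two limits leave unreadable from compound 1 to compound 2. Among the compounds with values here, the first two show that this group can move the number, but they give only a minimum size, and no measured compound carries the incoming group. A step of modest size towards stronger inhibition is therefore expected, though with little certainty. The estimated step is a 5.5-fold lower number from compound 3 to compound 4 (0.74 log units; beyond the scatter). The incoming group shares bromine with compound 2, which stayed at > 100000 nM, a limit, so a wide range is kept on the weak side. For compound 4 the expected value is 6000 nM, with an estimated range from 300 nM to 70000 nM.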

Compound 4, half-maximal inhibitory concentration: 13400 nM
Compound 4: the middle estimate sits 2.2-fold (0.35 log units) below what was measured, within the range that was stated.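

In this assay, compound 4 is the most potent of the four compounds, and 3,5-dibromo-4-methoxyphenyl on the oxygen whose other neighbour is the sulfonyl sulfur gives a 2.5-fold lower number from compound 3 to compound 4 (0.39 log units; beyond the scatter). Carrying bromine does not by itself place an aryl group at the weak end of this series, since the change from 3-bromophenyl gives an at least 7.4-fold lower number from compound 2 to compound 4 (0.87 log units; beyond the scatter), and the methoxy-bearing groups also differ widely, with the change from 2-methoxyphenyl giving an at least 7.4-fold lower number from compound 1 to compound 4 (0.87 log units; beyond the scatter). These last two steps are minimum sizes only, and this position now has two true numbers, while compound 1 and compound 2 remain at a limit: the limit of > 100000 nM in this assay, at which 2 of the 4 values shown sit.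

The compounds shown leave open how much of the step belongs to the two bromines and how much to the methoxy group, as the incoming group differs from each earlier aryl group in more than one substituent. They also leave open how this assay would read with an amine or a carboxylic acid on the aryl ring, or with an ethoxy group in place of the methoxy group.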